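A few compounds are considered here, and "the series" means these few. Any claim that something is new, unique, unknown or untested is made for them only; others in the source may bear on it.

Three compounds have been measured in an assay on HEK293 cells for displacement of a labelled ligand from NPC1-like intracellular cholesterol transporter 1 (Homo sapiens); a higher number here means a weaker inhibitor, a lower number a stronger inhibitor:

compound 1, `CC1(C)CC(OC(=O)CN2CN(c3ccccc3)C3(CCN(C(=O)c4ccc(C(C)(C)C)cc4)CC3)C2=O)CC(C)(C)N1`, 1300 nM
compound 2, `O=C(CN1CN(c2ccccc2)C2(CCN(C(=O)c3ccc(C4CCCCC4)cc3)CC2)C1=O)NCO`, 8300 nM
compound 3, `CS(=O)(=O)NCCNC(=O)CN1CN(c2ccccc2)C2(CCN(C(=O)c3ccc(C4CCCCC4)cc3)CC2)C1=O`, 2100 nM

Compound 1 and compound 3 lie within the scatter of each other in this assay, while compound 2 sits beyond the scatter from compound 1, at a higher number. Among the compounds with values here, the one step measured between compounds that differ in a single place is a 4.0-fold lower number from compound 2 to compound 3 (0.60 log units; beyond the scatter), which replaces one terminal group of the side chain on the amide-type nitrogen by another.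

Compound 4, `CC(C)(C)OC(=O)NCCCNC(=O)CN1CN(c2ccccc2)C2(CCN(C(=O)c3ccc(C(C)(C)C)cc3)CC2)C1=O`, is derived from compound 1 by the change ((3-((tert-butoxycarbonyl)amino)propyl)amino in place of (2,2,6,6-tetramethylpiperidin-4-yl)oxy on a carbonyl carbon). This bears on the same part of the molecule as the measured step: the substituent carried by the carbonyl carbon of the chain. That step was modest and shows that the terminus of this chain moves the number only moderately. The entering group of compound 4 resembles that of compound 3 more than that of compound 2 in carrying an extended chain with a further carbonyl, so no step beyond the scatter is expected from compound 1, though the direction is uncertain. The expected step is a 1.2-fold higher number from compound 1 to compound 4 (0.06 log units; within the scatter). Compound 4 is therefore estimated at 1500 nM, in a range from 500 nM to 5000 nM.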

Compound 4, half-maximal inhibitory concentration: 4500 nM
Beside the measured number, compound 4's estimate is 3.0-fold (0.48 log units) below it; measured number inside the range.
By their numbers in this assay, from the lowest: compounds 1 and 3 (each within the scatter of the next); then compounds 4 and 2 (each within the scatter of the next).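

In this assay, the change gives a 3.5-fold higher number from compound 1 to compound 4 (0.54 log units; beyond the scatter), so the substituent on this carbonyl carbon also moves the number beyond the scatter in a second pair of compounds, this time upward, whereas the earlier step ran downward: a 4.0-fold lower number from compound 2 to compound 3 (0.60 log units; beyond the scatter). The two pairs carry different groups at this position and differ elsewhere in the molecule, so they give no single ranking of these substituents, only evidence that the number responds to what is placed here. The new change is also a composite one, since the (2,2,6,6-tetramethylpiperidin-4-yl)oxy group with its six-membered ring gives way to the open (3-((tert-butoxycarbonyl)amino)propyl)amino chain, and nothing shown gives a reason for the rise or assigns it to one part of that exchange.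

Going by these compounds, it remains open whether the link or the ring matters more, a question that (2,2,6,6-tetramethylpiperidin-4-yl)amino on the same carbonyl carbon would address. Also open, on these data alone, is how the chain would fare as the free primary amine without the tert-butoxycarbonyl group, or with a shorter or longer chain.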